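Fluoro for hydroxy on a quinuclidine triazole phenol

The source may report more compounds than this note shows. Statements on the series, on what has been measured and on what is new or still open speak of the compounds shown alone.

The series rests on one bicyclic amine carrying a triazole and an aryl ring. For the measured compounds named here, in an assay on HEK293 cells for displacement of a labelled ligand from Neuronal acetylcholine receptor; alpha4/beta2 (Homo sapiens), read by scintillation counting, with a stated time of 120 min (on this read-out lower numbers stand for stronger inhibition and higher numbers for weaker inhibition), compound 1 `Oc1ccc(-c2cn([C@H]3CN4CCC3CC4)nn2)cc1` gives 7390 nM, and compound 2 `Oc1ccc(-c2cn([C@@H]3CN4CCC3CC4)nn2)cc1` gives 461 nM; the step of a 16-fold lower number from compound 1 to compound 2 (1.20 log units; beyond the scatter) is the only one between single-point neighbours, and it concerns configuration alone (the fact that one of compounds 1 and 2 is drawn with a defined configuration and the other without, at the place where they differ). Compound 3 `Fc1ccc(COc2cccc(-c3cn([C@@H]4CN5CCC4CC5)nn3)c2)cc1` gives 537 nM in this assay. Compound 2 thus has the lowest number of the three, with compound 3 within the scatter of it and compound 1 well beyond.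

Compound 4 `Fc1ccc(-c2cn([C@@H]3CN4CCC3CC4)nn2)cc1` differs from compound 2 by fluoro in place of hydroxy on an aromatic carbon. Going by the values given here, no measured step touches this position, so no direction can be read from the numbers. Compound 4 is therefore expected near the scatter edge, a step of a 2.2-fold higher number from compound 2 to compound 4 (0.34 log units; beyond the scatter), estimated at 1000 nM with a range of 300 nM to 3500 nM.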

Compound 4, inhibition constant: 515 nM
Compound 4: middle estimate off by 1.9-fold (0.29 log units), on the high side; the measured number falls inside the stated range.
By their numbers in this assay, from the lowest: compounds 2, 4 and 3 (each within the scatter of the next); then compound 1.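

At this position, on an aromatic carbon para to a large group, fluoro in place of hydroxy gives in this assay a 1.1-fold higher number from compound 2 to compound 4 (0.05 log units; within the scatter). For the compounds shown here, the number here therefore does not depend on keeping the hydrogen-bond donor and acceptor counted for hydroxy, which the earlier compounds could not show. Nothing available bears on why the two groups read alike. The compounds shown leave open how an amine, a methoxy group or a carboxylic acid would read at this position. They also leave open whether fluoro would read the same in the configuration of compound 1.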